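Swapping a Sulfur-Linked Ring for a Fluorinated Aromatic Ring

The compounds below may be only part of what the source reports. "The series", "measured", "known", "first", "only" and "open" are said of these compounds alone.

Of the compounds shown here, two built on one shared core have been measured in an assay on HEK cells for antagonist activity at transient receptor potential cation channel subfamily V member 1 (Homo sapiens), read by FLIPR; a lower number here means a stronger inhibitor, a higher number a weaker inhibitor. Compound 1 `CCCN(CCC)c1nc(C(F)(F)F)ccc1CNC(=O)Nc1cccc2[nH]c(=O)ccc12` gives 5.21 nM in this assay. Compound 2 `O=C(NCc1ccc(C(F)(F)F)nc1SC1CCCCC1)Nc1cccc2[nH]c(=O)ccc12` gives 2.15 nM in this assay, the lowest of the two numbers, with compound 1 as its nearest neighbour. For the measured compounds named here, the single measured step, a 2.4-fold lower number from compound 1 to compound 2 (0.38 log units; beyond the scatter), shows that exchanging the group on this aromatic carbon next to the ring nitrogen shifts the number modestly.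

Compound 3 `O=C(NCc1ccc(C(F)(F)F)nc1-c1ccc(F)cc1)Nc1cccc2[nH]c(=O)ccc12` differs from compound 2 at that same carbon: 4-fluorophenyl in place of cyclohexylsulfanyl on an aromatic carbon. Going by the values given here, no measured step compares a sulfur-linked ring with an aromatic ring, so the one step from compound 1 to compound 2 is only an indirect guide. Because that earlier exchange at this carbon gave a 2.4-fold lower number from compound 1 to compound 2 (0.38 log units; beyond the scatter), the new exchange is expected to move this assay by a comparable or smaller amount, in either direction, quite possibly staying within the scatter. Compound 3 is therefore estimated at 3.5 nM in this assay, with a range from 1 nM to 12 nM. The expected step is a 1.6-fold higher number from compound 2 to compound 3 (0.21 log units; within the scatter).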

Compound 3, half-maximal inhibitory concentration: 1.93 nM
Beside the measured number, compound 3's estimate is 1.8-fold (0.26 log units) above it; measured number inside the range.
By their numbers in this assay, from the lowest: compounds 3 and 2 (each within the scatter of the next); then compound 1.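

At this carbon next to the ring nitrogen, in this assay, an aromatic ring serves as well as a sulfur-linked non-aromatic ring: the exchange gives only a 1.1-fold lower number from compound 2 to compound 3 (0.05 log units; within the scatter) even though 4-fluorophenyl and cyclohexylsulfanyl differ in ring type, in the linking atom and in the presence of fluorine. The comparison with the dipropylamino group also widens, as the measured 2.7-fold lower number from compound 1 to compound 3 (0.43 log units; beyond the scatter) is beyond the scatter, so among these three compounds the lower number seen for compound 2 is no longer unique to cyclohexylsulfanyl and appears with 4-fluorophenyl too. No measurement shown here accounts for why these two different groups give matching numbers.

Since the exchange alters several features at once, these compounds cannot say which feature, if any, matters at this carbon; a plain phenyl ring or a cyclohexyl ring joined directly to the carbon would begin to separate them. Going by these compounds, it also remains open how far this carbon tolerates a much smaller group, such as methyl, or a ring containing nitrogen, such as pyridine.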